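The source may hold more compounds than are shown below. What is called first, only, known or untested is meant among the compounds shown, and "the series" means these compounds.

Measured so far, in an ADME assay on Left cardiac atrium (Cavia porcellus); a higher number here means that more compound is needed for the effect, a lower number that less compound is needed:

Compound 1 `CCOC(=O)C1=C(C)NC(C)=C(C(=O)OCC)C1c1c(-c2ccc(OC(F)(F)F)cc2)nc2sc(Br)cn12`: compound 1 gives 93 nM.
Compound 2 `CCOC(=O)C1=C(C)NC(C)=C(C(=O)OCC)C1c1c(-c2ccc(F)cc2)nc2sccn12`: compound 2 gives 64 nM.
Compound 3 `CCOC(=O)C1=C(C)NC(C)=C(C(=O)OCC)C1c1c(-c2ccc(F)cc2)nc2sc(Cl)cn12`: compound 3 gives 49 nM.

Compound 3 has the lowest number of the three, but its gaps to compound 2 and to compound 1 are both within the scatter, so the three compounds cannot be told apart on these numbers. Within the data shown here, the only single-point step seen so far, a 1.3-fold lower number from compound 2 to compound 3 (0.12 log units; within the scatter), touched the five-membered ring and changed little.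

Compound 4 `CCOC(=O)C1=C(C)NC(C)=C(C(=O)OCC)C1c1c(-c2cc([N+](=O)[O-])c(Cl)cc2Cl)nc2sc(Cl)cn12` carries a different change: 2,4-dichloro-5-nitrophenyl in place of 4-fluorophenyl on an aromatic carbon. Among the measured compounds shown here, no measured step alters this phenyl group, so nothing here bears directly on it. Compound 1 differs from compound 2 in two places, one of them on the phenyl group, and their values sit within the scatter of each other, which hints that changes there may matter little, though that is a loose hint. The step of a 2.0-fold higher number from compound 3 to compound 4 (0.31 log units; beyond the scatter) is therefore expected to be small, with a wide margin. Compound 4 is estimated at 100 nM, between 30 nM and 350 nM.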

Compound 4, half-maximal effective concentration: 81 nM
For compound 4 the middle estimate is 1.2-fold (0.09 log units) above the measured one, within the range that was stated.
By their numbers in this assay, from the lowest: compounds 3, 2, 4 and 1 (each within the scatter of the next).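

Among these compounds, compound 3 and compound 4 give the first comparison that changes only the phenyl group on the aromatic carbon of the five-membered ring. In this assay, putting 2,4-dichloro-5-nitrophenyl in place of 4-fluorophenyl gives a 1.7-fold higher number from compound 3 to compound 4 (0.22 log units; within the scatter), so this pair cannot be told apart even though the entering group carries two chlorines and a nitro group that the leaving group lacks. No measurement is available here that would explain this result.

The chlorines, the nitro group and the loss of the fluorine all arrive in one step, so the part played by each remains unresolved, and opposing contributions cannot be ruled out. Going by these compounds, it also remains open whether the same holds for groups of a different kind at this position, such as a phenyl ring bearing an amine or a carboxylic acid, or a longer alkyl chain in place of the ring.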